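Adding a methyl to the hydroxylated ester side chain

The source may report more compounds than this note shows. Statements on the series, on what has been measured and on what is new or still open speak of the compounds shown alone.

Three analogues sharing the core of compound 1 `CC[C@@](C)(O)CC(=O)O[C@H](CC=C(C)C)C1=CC(=O)c2c(O)ccc(O)c2C1=O` have been measured in a functional assay on DU-145 cells (Homo sapiens) for cytotoxicity, read by MTT assay; on this read-out lower numbers stand for stronger inhibition and higher numbers for weaker inhibition. Compound 1 gives 12700 nM in this assay. Compound 2 `CC(C)=CC[C@@H](OC(=O)C1CCCO1)C1=CC(=O)c2c(O)ccc(O)c2C1=O`, which carries an oxolan-2-yl on the carbonyl carbon, gives 10500 nM in this assay, a change of a 1.2-fold lower number from compound 1 to compound 2 (0.08 log units; within the scatter). Compound 3 `CC[C@](C)(O)CC(=O)O[C@H](CC=C(C)C)C1=CC(=O)c2c(O)ccc(O)c2C1=O` gives 20500 nM in this assay; it differs from compound 1 only in configuration as drawn, and the step is a 1.6-fold higher number from compound 1 to compound 3 (0.21 log units; within the scatter). From compound 2 the step is a 2.0-fold higher number from compound 2 to compound 3 (0.29 log units; within the scatter). Compound 3 thus shows the highest of the three numbers, but every step to it lies within the scatter, so none of the three can be set apart from the others.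

Compound 4 `CC(C)=CC[C@@H](OC(=O)CC(C)(O)C(C)C)C1=CC(=O)c2c(O)ccc(O)c2C1=O` has not yet been measured. Its difference from compound 3 is 1-hydroxy-1,2-dimethylpropyl in place of 1-hydroxy-1-methylpropyl on a saturated chain carbon bound to a carbonyl carbon. Among the measured compounds shown here, no measured step adds a methyl to this chain; the only steps that touch the ester side chain, a 1.2-fold lower number from compound 1 to compound 2 (0.08 log units; within the scatter) and a 2.0-fold higher number from compound 2 to compound 3 (0.29 log units; within the scatter), both stay within the scatter, as does the configurational step a 1.6-fold higher number from compound 1 to compound 3 (0.21 log units; within the scatter). The expected step is therefore a 1.1-fold lower number from compound 3 to compound 4 (0.06 log units; within the scatter), with no change beyond the scatter. Compound 4 is estimated at 18000 nM in this assay, within the range 8000 nM to 40000 nM.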

Compound 4, half-maximal inhibitory concentration: 16900 nM
Beside the measured number, compound 4's estimate is 1.1-fold (0.03 log units) above it, and the stated range covers the measured number.
By their numbers in this assay, from the lowest: compounds 2, 1, 4 and 3 (each within the scatter of the next).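

In this assay, the added methyl, 1-hydroxy-1,2-dimethylpropyl in place of 1-hydroxy-1-methylpropyl on a saturated chain carbon bound to a carbonyl carbon, stays within the scatter, with a 1.2-fold lower number from compound 3 to compound 4 (0.08 log units; within the scatter) and a 1.3-fold higher number from compound 1 to compound 4 (0.12 log units; within the scatter). Among the compounds shown here, the exchange of the ring-bearing oxolan-2-yl for the larger open chain 2-hydroxy-2,3-dimethylbutyl on a carbonyl carbon also stays within the scatter, with a 1.6-fold higher number from compound 2 to compound 4 (0.21 log units; within the scatter), so this position now accepts a further chain variant with no step that sets it apart. The same exchange of groups describes the steps to compound 4 from both compound 1 and compound 3 because these two starting compounds have the same atoms and bonds: the fact that compounds 1 and 3 differ only in the configuration as drawn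

The compounds shown leave open whether an amine or a carboxylic acid on this side chain, or a longer chain than 2-hydroxy-2,3-dimethylbutyl, would give a step beyond the scatter. Also open, on these data alone, is whether the configuration at the hydroxyl-bearing carbon matters in compound 4, whose entering group has no defined stereocentre as drawn.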